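Thiourea Variation on a Chloroquinoline Core

The source may hold more compounds than are shown below. What is called first, only, known or untested is meant among the compounds shown, and "the series" means these compounds.

Compound 1 `OCCNC(=S)Nc1ccnc2cc(Cl)ccc12`, compound 1 gives > 50000 nM
Compound 2 `S=C(Nc1ccnc2cc(Cl)ccc12)N1CCNCC1`, compound 2 gives "not determined" (no result reported)

Compound 1 carries a hydroxyethyl thiourea on the shared core. In a functional assay on HeLa cells (Homo sapiens) for cytotoxicity, read by MTT assay, with a stated time of 7 h (a lower number here means a stronger inhibitor, a higher number a weaker inhibitor), compound 1 gives > 50000 nM, which is a limit of the assay rather than a number. Compound 2 carries a piperazine thiourea on the same core, and for compound 2 no result was reported in this assay. So compound 1 stands at the limit, where one of the two entries sits (the limit of > 50000 nM in this assay, at which 1 of the 2 values shown sits), and no single number is known for any compound.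

Compound 3 `CCN(CC)CCCNC(=S)Nc1ccnc2cc(Cl)ccc12` differs from compound 1 by (diethylamino)methyl in place of hydroxy on a saturated chain carbon, two bonds along the chain from an amide-type nitrogen. For the measured compounds named here, no step between measured compounds is available, so the size of this change can only be expected, not read off. Because compound 1 sits at > 50000 nM, compound 3 is estimated at 40000 nM, with a range from 8000 nM to 100000 nM. The expected step of an at least 1.2-fold lower number from compound 1 to compound 3 (0.09 log units; that floor lies within the scatter) is toward a somewhat stronger inhibitor, but it may well remain within the scatter, and a further limit is considered more likely than a number.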

Compound 3, half-maximal inhibitory concentration: 49200 nM
Beside the measured number, compound 3's estimate is 1.2-fold (0.09 log units) below it; measured number inside the range.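

For the compounds shown here, at this place, on a saturated chain carbon, two bonds along the chain from an amide-type nitrogen, the change from hydroxy to (diethylamino)methyl yields the first single number on the shared core: in this assay compound 3 gives 49200 nM. The change reads as an at least 1.0-fold lower number from compound 1 to compound 3 (0.00 log units; that floor lies within the scatter), so the data do not establish a shift beyond the scatter, though they do not exclude one either. The value of compound 1 is a limit of the assay, so this step has a floor and no known full size: the limit of > 50000 nM in this assay, at which 1 of the 3 values shown sits.

Going by these compounds alone, it remains open whether a shorter chain, a longer chain, a primary amine or a carboxylic acid at this place would give a clearly different number, and whether the diethylamino group or the added chain length accounts for the single number seen with compound 3. Compound 2 offers no value for comparison, so the piperazine thiourea on the same core cannot be placed relative to compound 1 or compound 3 in this assay.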